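A few compounds are considered here, and "the series" means these few. Any claim that something is new, unique, unknown or untested is made for them only; others in the source may bear on it.

Working notes on the series. Compound 1 `C=CC(=O)Nc1cccc(Nc2ncnc(Nc3ccc(-c4cccnc4)cc3)n2)c1` is the parent. In a functional assay on Ramos cells (Homo sapiens) for antiproliferative activity, read by CCK-8 assay, with a stated time of 24 h (on this read-out lower numbers stand for stronger inhibition and higher numbers for weaker inhibition), compound 1 gives only a limit, > 100000 nM. That limit is the limit of > 100000 nM in this assay, at which 1 of the 2 values shown sits. Compound 2 `C=CC(=O)Nc1cccc(Nc2ncnc(Nc3ccc(-c4ccc(F)nc4)cc3)n2)c1` carries fluoro in place of hydrogen on an aromatic carbon; in this assay compound 2 gives 59200 nM. The step is an at least 1.6-fold lower number from compound 1 to compound 2 (0.22 log units; that floor lies within the scatter). Compound 2 therefore holds the only number shown; the one further value is a limit.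

Compound 3 `C=CC(=O)Nc1cccc(Nc2ncnc(Nc3ccc(C(=O)Nc4ccc(C)cn4)cc3)n2)c1` differs from compound 2 by (5-methylpyridin-2-yl)carbamoyl in place of 6-fluoropyridin-3-yl on an aromatic carbon. No measured step touches this part of the molecule; the only step shown, from compound 1 to compound 2, concerns a fluorine and does not inform the new amide-linked pyridine. The step in this assay from compound 2 to compound 3 is therefore expected to be a 1.5-fold lower number from compound 2 to compound 3 (0.17 log units; within the scatter), with wide uncertainty. Compound 3 is estimated at 40000 nM, between 8000 nM and 200000 nM.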

Compound 3, half-maximal inhibitory concentration: > 100000 nM
Compound 3 was reported as a limit; the forecaster's own chance of this, stated with the estimate: 30%; middle value at least 2.5-fold (0.39 log units) from the limit.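

In this assay, moving from a directly attached 6-fluoropyridin-3-yl to the carbamoyl-linked (5-methylpyridin-2-yl)carbamoyl on the same aromatic carbon gives an at least 1.6-fold higher number from compound 2 to compound 3 (0.22 log units; that floor lies within the scatter), so this larger group brings no readable gain at this position. Compound 3 gives a limit and not a number, and it joins compound 1 there: the limit of > 100000 nM in this assay, at which 2 of the 3 values shown sit. The step between compound 1 and compound 3 cannot be read, as both values are limits.

The compounds shown do not separate the carbamoyl link from the change in the pyridine ring and its methyl. Going by these compounds, what an amine, a carboxylic acid or a longer chain on this aromatic carbon would give stays open, as does whether any group here brings the series clear of the limit.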